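Removing a Ring-Borne Group and Cell Toxicity

This account rests on a few compounds, and the source may have more. Where it says the series, first, only, none or still open, it means among the compounds named here.

Compound 1, `Cc1cc(C)cc(S(=O)(=O)c2c(C(=O)NC3CC4(CCNCC4)C3)[nH]c3ccc(Cl)cc23)c1`, in a toxicity assay on MT4 cells (Homo sapiens) for cytotoxicity, read by MTT assay, with a stated time of 7 days; on this read-out lower numbers stand for higher toxicity in this test and higher numbers for lower toxicity in this test: 24200 nM
Compound 2, `Cc1cc(C)cc(S(=O)(=O)c2c(C(=O)NC3CC4(CCN(Cc5n[nH]c(=O)n5C)CC4)C3)[nH]c3ccc(Cl)cc23)c1`, in this assay: 178000 nM
Compound 3, `Cc1cc(C)cc(S(=O)(=O)c2c(C(=O)NC3CC4(C3)CN(Cc3n[nH]c(=O)n3C)C4)[nH]c3ccc(Cl)cc23)c1`, in this assay: 65600 nM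

All three compounds share the same sulfone-bearing indole amide, and they differ only in the spiro-fused amine part at the other end. Compound 2 and compound 1 differ in one place: a hydrogen atom in place of a group of 8 heavy atoms (4 carbon, 3 nitrogen, 1 oxygen; one five-membered aromatic ring with 3 hetero atoms), on an amine nitrogen in a ring. This change gave a 7.4-fold lower number from compound 2 to compound 1 (0.87 log units; beyond the scatter), so taking the group off made the compound more toxic to the cells. Compound 3 carries the same group on a smaller amine ring; how the core of compound 3 differs from that of compound 2 is not broken down here. Compound 3 sits between the other two in this assay.

Compound 4, `Cc1cc(C)cc(S(=O)(=O)c2c(C(=O)NC3CC4(CNC4)C3)[nH]c3ccc(Cl)cc23)c1`, is not yet measured. It comes from compound 3 by a hydrogen atom in place of a group of 8 heavy atoms (4 carbon, 3 nitrogen, 1 oxygen; one five-membered aromatic ring with 3 hetero atoms), on an amine nitrogen in a ring. This is the same kind of change as that from compound 2 to compound 1, but the place is not the same: in compound 2 the nitrogen lies in a six-membered non-aromatic ring with three ring bonds from the shared atom, in compound 3 in a four-membered non-aromatic ring with two ring bonds from the shared atom. In this assay compound 4 is expected to show a 5.5-fold lower number from compound 3 to compound 4 (0.74 log units; beyond the scatter), resting on the step from compound 2 to compound 1, which was a 7.4-fold lower number from compound 2 to compound 1 (0.87 log units; beyond the scatter). The surroundings differ, and a somewhat smaller shift is estimated. The estimate for compound 4 is 12000 nM, expected to fall between 4000 nM and 36000 nM.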

Compound 4, half-maximal cytotoxic concentration: 28600 nM
For compound 4 the middle estimate is 2.4-fold (0.38 log units) below the measured one; measured number inside the range.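

In this assay the direction of the change carried over from one core to the other: replacing the group with a hydrogen atom made the compound more toxic to the cells on both, and on the four-membered non-aromatic ring this gave a 2.3-fold lower number from compound 3 to compound 4 (0.36 log units; beyond the scatter). The size of the change did not carry over, and the two steps differ by more than repeated measurements would normally explain: the same change on two cores in this assay, a 7.4-fold lower number (0.87 log units; beyond the scatter) from compound 2 to compound 1 and a 2.3-fold lower number (0.36 log units; beyond the scatter) from compound 3 to compound 4, 3.2-fold (0.51 log units) apart, beyond the scatter of two such steps. Two pairs show only that the size of this step can depend on the core, not what sets it or how large it would be on a third core, while the two compounds without the group are not separated in this test, with a 1.2-fold higher number from compound 1 to compound 4 (0.07 log units; within the scatter).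

The compounds shown leave open whether the smaller step belongs to this particular group or would also appear with others on the same ring nitrogen, such as an acetyl group or a longer chain ending in a carboxylic acid. They also leave open how the change affects anything other than toxicity to these cells.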